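Piperidine to methylpiperazine on the propoxy chain

The source may hold more compounds than are shown below. What is called first, only, known or untested is meant among the compounds shown, and "the series" means these compounds.

Compound 2 `COc1cc2c(Oc3ccc(NC(=O)c4cn(-c5ccccc5F)nn4)cc3F)ccnc2cc1OCCCN1CCCCC1` was tested in a functional assay on HT-29 cells (Homo sapiens) for cytotoxicity, read by MTT assay, with a stated time of 72 h (on this read-out lower numbers stand for stronger inhibition and higher numbers for weaker inhibition), where compound 2 gives 290 nM. Among the two compounds measured, compound 2 has the highest number; the nearest is compound 1 `COc1cc2c(Oc3ccc(NC(=O)c4cn(-c5ccccc5)nn4)cc3F)ccnc2cc1OCCCN1CCCCC1`, which in this assay gives 180 nM, and the two values lie within the scatter of each other. For the measured compounds named here, the only measured step, a 1.6-fold higher number from compound 1 to compound 2 (0.21 log units; within the scatter), concerns a fluoro in place of hydrogen on an aromatic carbon and does not touch the part of the molecule changed next. Compound 3 `COc1cc2c(Oc3ccc(NC(=O)c4cn(-c5ccccc5F)nn4)cc3F)ccnc2cc1OCCCN1CCN(C)CC1` differs from compound 2 in one place: 4-methylpiperazin-1-yl in place of piperidin-1-yl on a saturated chain carbon, three bonds along the chain from an oxygen on an aromatic ring. Going by the values given here, no measured step bears on this change, so nothing in the data points to a direction, and a step within the scatter is the plain expectation for this assay. Compound 3 is therefore estimated at 300 nM, with a range of 100 nM to 900 nM, which means an expected step of a 1.0-fold higher number from compound 2 to compound 3 (0.01 log units; within the scatter).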

Compound 3, half-maximal inhibitory concentration: 300 nM
Beside the measured number, compound 3's estimate shows no gap at the digits printed; low and high end bracket the measured number.
By their numbers in this assay, from the lowest: compounds 1, 2 and 3 (each within the scatter of the next).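

In this assay, placing 4-methylpiperazin-1-yl where piperidin-1-yl stood, on a saturated chain carbon, three bonds along the chain from an oxygen on an aromatic ring, gives a 1.0-fold higher number from compound 2 to compound 3 (0.01 log units; within the scatter) and so no change that can be told from the scatter. For the compounds shown here, this is the first reading at this position, as the earlier compounds both carry piperidin-1-yl, and it shows that the second ring nitrogen and its methyl group leave the number in this cytotoxicity read-out where it was. Nothing measured here speaks to why the two groups read alike.

From the compounds shown here alone, whether the exchange reads the same on compound 1, which lacks the fluoro, stays open. So does what a morpholine, a dimethylamino group or an unsubstituted piperazine would give at the end of this chain, or a longer chain carrying the same 4-methylpiperazin-1-yl.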